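Working notes: step from compound 3 to compound 4

A few compounds are considered here, and "the series" means these few. Any claim that something is new, unique, unknown or untested is made for them only; others in the source may bear on it.

Values in an ADME assay on NHDF cells (Homo sapiens) for cytotoxicity, read by MTT assay, with a stated time of 72 h; on this read-out lower numbers stand for stronger inhibition and higher numbers for weaker inhibition:
- compound 1 `COc1ccc(/C=C2\CCC/C(=C\c3cccc(Br)c3)C2=O)cc1OC`: 12400 nM
- compound 2 `COc1ccc(/C=C2\CCC/C(=C\c3ccc(OC)c(OC)c3)C2=O)cc1`: 30900 nM
- compound 3 `COc1ccc(/C=C2\CCC/C(=C\c3ccc(Cl)cc3Cl)C2=O)cc1OC`: > 50000 nM (a limit, not a number)

Compound 3 gives only a limit, > 50000 nM, and no number. Compound 3 sits at the limit of > 50000 nM in this assay, at which 1 of the 3 values shown sits. Its true position can therefore not be placed on the numbers shown.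

Compound 4 `COc1ccc(/C=C2\CCC/C(=C\c3ccc(O)c(O)c3)C2=O)cc1OC` has 3,4-dihydroxyphenyl in place of 2,4-dichlorophenyl on a double-bonded chain carbon bound to a double-bonded ring carbon.

Among the compounds with values here, three measured steps concern this same place. They are a 2.5-fold higher number from compound 1 to compound 2 (0.40 log units; beyond the scatter), an at least 4.0-fold higher number from compound 1 to compound 3 (0.60 log units; beyond the scatter) and an at least 1.6-fold higher number from compound 2 to compound 3 (0.20 log units; that floor lies within the scatter). The first two lie beyond the scatter and are modest or at least modest, while the floor of the third lies within it. Within the data shown here, no measured compound carries the 3,4-dihydroxyphenyl group, so these steps give only a rough scale. The expectation leans on compound 2 at 30900 nM and compound 1 at 12400 nM, both of which gave numbers in this assay. A modest move to a lower number is expected, with the expected step being an at least 2.7-fold lower number from compound 3 to compound 4 (0.44 log units; beyond the scatter). For compound 4 the estimated value is 18000 nM, with an expected range from 5000 nM to 50000 nM.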

Compound 4, half-maximal inhibitory concentration: 25200 nM
Compound 4: middle estimate off by 1.4-fold (0.15 log units), on the low side; the range from low to high includes it.
By their numbers in this assay, from the lowest: compound 1; then compounds 4 and 2 (each within the scatter of the next). At a limit, above all of these: compound 3.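

In this assay, 3,4-dihydroxyphenyl is the first group shown with hydrogen-bond donors on a double-bonded chain carbon bound to a double-bonded ring carbon, and its result cannot be told apart from that of the 4-methoxyphenyl group: a 1.2-fold lower number from compound 2 to compound 4 (0.09 log units; within the scatter). Set against the 3-bromophenyl group, the same change gives a modest step, and compound 1 keeps the lowest number among the compounds shown: a 2.0-fold higher number from compound 1 to compound 4 (0.31 log units; beyond the scatter). Set against the 2,4-dichlorophenyl group, the step has only a floor, an at least 1.9-fold lower number from compound 3 to compound 4 (0.29 log units; that floor lies within the scatter), and the value of compound 3 is a limit, not a number, so the true size of this step stays unplaced: the limit of > 50000 nM in this assay, at which 1 of the 4 values shown sits.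

Still open, as far as these compounds go, is whether an amine or a carboxylic acid on the phenyl group at this place would move the number away from those of compound 2 and compound 4, or leave it there. The compounds shown also do not tell whether a single hydroxyl group on the phenyl group would give the same result as the two hydroxyl groups of compound 4.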